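Swapping Propyl for Carboxy on a Kinase Inhibitor Scaffold

A few compounds are considered here, and "the series" means these few. Any claim that something is new, unique, unknown or untested is made for them only; others in the source may bear on it.

Compound 2 `CCCc1ccc(C(=O)Nc2cccc(NC(=O)COc3ccc4c(=O)ccoc4c3)c2)cc1` was tested in an assay on isolated protein for inhibition of Rho-associated protein kinase 1 (Homo sapiens), read by scintillation counting, radiometric assay and 33P incorporation, with a stated time of 40 min, in the presence of a further agent that is not named here (on this read-out lower numbers stand for stronger inhibition and higher numbers for weaker inhibition), where compound 2 gives 143 nM. Compound 1 `CN(C)c1ccc(C(=O)Nc2cccc(NC(=O)COc3ccc4c(c3)OCCC4=O)c2)cc1` gives 144 nM in this assay; the two numbers lie within the usual scatter of each other, so neither compound can be set apart from the other. Compound 3 `O=C(COc1ccc2c(=O)ccoc2c1)Nc1cccc(NC(=O)c2ccc(C(=O)O)cc2)c1` has not yet been measured. It differs from compound 2 in one place: carboxy in place of propyl on an aromatic carbon. Going by the values given here, no measured pair shows this kind of change, so there is no direct guide. Compound 3 is expected to show somewhat weaker inhibition, the estimated step being a 2.4-fold higher number from compound 2 to compound 3 (0.39 log units; beyond the scatter). Compound 3 is therefore estimated at 350 nM, within a range from 120 nM to 1200 nM.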

Compound 3, half-maximal inhibitory concentration: 6890 nM
For compound 3 the middle estimate is 20-fold (1.29 log units) below the measured one; the whole stated range lies below it.
By their numbers in this assay, from the lowest: compounds 2 and 1 (each within the scatter of the next); then compound 3.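

Carboxy in place of propyl on this aromatic carbon brings a 48-fold higher number from compound 2 to compound 3 (1.68 log units; beyond the scatter) and so a large loss of inhibition. Going by these compounds alone, although both groups have the same count of heavy atoms, they are far from interchangeable here, which the earlier compounds, with no pair differing in one place, could not show. Nothing available explains the size of this step.

On these data alone, whether an amine, a methyl ester or a longer chain at this position would keep the inhibition of compound 2 stays open. So does whether carboxy would cost as much on the core of compound 1.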